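Trifluoromethyl for chloro on a phenoxy arm

This account rests on a few compounds, and the source may have more. Where it says the series, first, only, none or still open, it means among the compounds named here.

Measured compounds:
compound 1, `CNC(=O)c1cccc(Cn2nc(C)c(NC(=O)c3ccc(COC4CCCCC4)cc3)c2C)c1`, 14000 nM
compound 2, `CNC(=O)c1cccc(Cn2nc(C)c(NC(=O)c3ccc(COc4ccccc4Cl)cc3)c2C)c1`, 6300 nM

Two compounds of one series share a core and differ only in the group carried on the oxygen of the saturated carbon. In a functional assay on MIA PaCa-2 cells (Homo sapiens) for antiproliferative activity, read by MTT assay, with a stated time of 72 h (on this read-out lower numbers stand for an effect already at smaller amounts and higher numbers for an effect only at larger amounts of compound), compound 1 gives 14000 nM. Within the data shown here, compound 2, with 2-chlorophenyl in place of cyclohexyl, gives 6300 nM in this assay, which is the lowest of the two numbers; the only step to it is a 2.2-fold lower number from compound 1 to compound 2 (0.35 log units; beyond the scatter).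

Compound 3, `CNC(=O)c1cccc(Cn2nc(C)c(NC(=O)c3ccc(COc4ccccc4C(F)(F)F)cc3)c2C)c1`, is not yet measured. It differs from compound 2 by trifluoromethyl in place of chloro on an aromatic carbon. Among the measured compounds shown here, no measured step swaps one substituent on that aromatic ring for another; the single known step, a 2.2-fold lower number from compound 1 to compound 2 (0.35 log units; beyond the scatter), replaces the whole cyclohexyl by an aromatic ring and so does not bear directly on this smaller change. With nothing in the data to point either way, the expectation for compound 3 in this assay is a step of a 1.1-fold lower number from compound 2 to compound 3 (0.02 log units; within the scatter), which is no change beyond the scatter. The estimate for compound 3 is 6000 nM, within 2500 nM to 15000 nM.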

Compound 3, half-maximal effective concentration: 10000 nM
Compound 3: middle estimate off by 1.7-fold (0.22 log units), on the low side; low and high end bracket the measured number.
By their numbers in this assay, from the lowest: compounds 2, 3 and 1 (each within the scatter of the next, the first and the last beyond it).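

In this assay, among these compounds, this is the first change on the aromatic ring itself: at the carbon ortho to a large group, trifluoromethyl, with 4 heavy atoms, enters where chloro, with 1, left. It comes to a 1.6-fold higher number from compound 2 to compound 3 (0.20 log units; within the scatter) and so cannot be told from the scatter, which means this position accepts the larger group without a clear shift in the number. Measured against the cyclohexyl compound, the result is a 1.4-fold lower number from compound 1 to compound 3 (0.15 log units; within the scatter) and again lies within the scatter, so the clear separation from compound 1 seen with 2-chlorophenyl does not hold for 2-(trifluoromethyl)phenyl, and compound 3 goes against any rule that an aromatic ring alone outperforms cyclohexyl here. No measurement at hand offers an explanation for these numbers.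

The compounds shown leave open how a methoxy group, an amine or a carboxylic acid on that same aromatic carbon would read, and whether a plain phenyl ring would sit closer to compound 1 or to compound 2. They also leave open whether, in this assay, compound 2 at 6300 nM is close to the lowest number this arm can give or whether another group would go well beyond it.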